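Phenyl carbamate in place of allyl on a selenocyanate

The source may report more compounds than this note shows. Statements on the series, on what has been measured and on what is new or still open speak of the compounds shown alone.

Three aryl selenium carbamates have been tested in a functional assay on PC-3 cells (Homo sapiens) for cytotoxicity, read by MTT assay, with a stated time of 72 h; on this read-out higher numbers stand for weaker inhibition of growth and lower numbers for stronger inhibition of growth. Compound 1 `N#C[Se]c1ccc(NC(=O)OCc2ccc([N+](=O)[O-])cc2)cc1` gives 9000 nM, compound 2 `C=CCOC(=O)Nc1ccc([Se]C#N)cc1` gives 17600 nM, and compound 3 `CCCCOC(=O)Nc1ccc([Se][Se]c2ccc(NC(=O)OCCCC)cc2)cc1` gives 28600 nM. Compound 2 stands second highest of these three numbers; its nearest neighbour is compound 3 and its furthest is compound 1, and both gaps lie within the scatter, so no order among the three can be claimed. Compound 4 `N#C[Se]c1ccc(NC(=O)Oc2ccccc2)cc1` has not yet been measured in this assay. It differs from compound 2 by phenyl in place of allyl on an oxygen next to a carbonyl group. Among the compounds with values here, no step of this kind has been measured here, so its size and direction are open; nothing beyond the scatter is expected. Compound 4 is expected at 12000 nM, within 4000 nM to 40000 nM. The estimated step of a 1.5-fold lower number from compound 2 to compound 4 (0.17 log units; within the scatter) is expected to stay within the scatter.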

Compound 4, concentration for 50% growth inhibition: 9100 nM
Beside the measured number, compound 4's estimate is 1.3-fold (0.12 log units) above it; the range from low to high includes it.
By their numbers in this assay, from the lowest: compounds 1, 4, 2 and 3 (each within the scatter of the next, the first and the last beyond it).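

The first step measured at this oxygen in this assay is a 1.9-fold lower number from compound 2 to compound 4 (0.29 log units; within the scatter), so phenyl in place of allyl leaves the number within the scatter. On the selenocyanate, then, this position carries an aromatic ring as well as a group with a double bond, with no change that can be read. Nothing measured explains this result. On these data alone, whether an amine or a carboxylic acid on the phenyl ring would move the number beyond the scatter remains open. So does whether the same change behaves alike on a diselenide.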